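This account rests on a few compounds, and the source may have more. Where it says the series, first, only, none or still open, it means among the compounds named here.

Measured so far in an assay on isolated protein for agonist activity at Bile acid receptor (Homo sapiens), read by TR-FRET; on this read-out higher numbers stand for an effect only at larger amounts of compound and lower numbers for an effect already at smaller amounts:
- compound 1, `CC(C)c1onc(-c2c(Cl)cccc2Cl)c1COc1ccc(-c2nc3ccc(C(=O)O)cc3n2CC(C)(C)C)cc1`: 24.8 nM
- compound 2, `CC(C)c1onc(-c2c(Cl)cccc2Cl)c1COc1ccc(-c2nc3ccc(C(=O)O)cc3n2C(C)C)cc1`: 56.7 nM
- compound 3, `CC(C)c1onc(-c2c(Cl)cccc2Cl)c1COc1ccc(-c2nc3ccc(C(=O)O)cc3n2C2CCC2)cc1`: "not determined" (no result reported)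

Compound 2 gives the highest of the two numbers at hand; its nearest neighbour is compound 1, and the step of a 2.3-fold higher number from compound 1 to compound 2 (0.36 log units; beyond the scatter) is beyond the scatter, so compound 2 sits the weaker of the pair. Compound 3 gives no number to place it.

Compound 4, `CCCC(CCC)n1c(-c2ccc(OCc3c(-c4c(Cl)cccc4Cl)noc3C(C)C)cc2)nc2ccc(C(=O)O)cc21`, differs from compound 2 in one place: 1-propylbutyl in place of isopropyl on an aromatic nitrogen

Within the data shown here, only one measured step bears on this change, the one from neopentyl to isopropyl on the aromatic nitrogen, a 2.3-fold higher number from compound 1 to compound 2 (0.36 log units; beyond the scatter), where the smaller group went with the higher number. The change to 1-propylbutyl moves in the other direction, to a larger group on the same aromatic nitrogen, so a lower number for compound 4 is expected, of roughly the same size as that step, though the shape of 1-propylbutyl is not the same as neopentyl and the match is loose. The expected step is a 1.9-fold lower number from compound 2 to compound 4 (0.28 log units; within the scatter). For compound 4 the estimate in this assay is 30 nM, with a range from 12 nM to 80 nM.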

Compound 4, half-maximal effective concentration: 30.3 nM
The estimate for compound 4 lay 1.0-fold (0.00 log units) below the measured number, and the stated range covers the measured number.
By their numbers in this assay, from the lowest: compounds 1, 4 and 2 (each within the scatter of the next, the first and the last beyond it).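

In this assay the aromatic nitrogen accepts 1-propylbutyl, with 7 heavy atoms against 3 for isopropyl, but the step, a 1.9-fold lower number from compound 2 to compound 4 (0.27 log units; within the scatter), stays within the scatter, so this change alone cannot be read as a gain. The step of a 1.2-fold higher number from compound 1 to compound 4 (0.09 log units; within the scatter) is also within the scatter, so 1-propylbutyl and neopentyl cannot be told apart here, and the separation beyond the scatter remains only between compound 1 and compound 2. No data at hand explain these numbers.

On these data alone, with no result reported for compound 3, the place of a cyclobutyl ring on this nitrogen stays open. Also open, as far as these compounds go, is whether a straight hexyl chain, or a chain carrying an amine or a hydroxyl group, would stay in this range in this assay.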